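A few compounds are considered here, and "the series" means these few. Any claim that something is new, unique, unknown or untested is made for them only; others in the source may bear on it.

Measured in a functional assay on the whole organism (Myocardium) with Canis familiaris (Canis lupus familiaris) as the target, at a dose of 8.75 mg/kg by the intravenous route; a higher number here means that more compound is needed for the effect, a lower number that less compound is needed:
- Compound 1 `COc1cc2nc(O)nc(C)c2cc1OC`: 2.42 mg/kg.
- Compound 2 `COc1cc2nc(O)nc(C(C)C)c2cc1OC`: 1.39 mg/kg.
- Compound 3 `COc1cc2nc(O)nc(C3CCCC3)c2cc1OC`: > 8.75 mg/kg.

In this assay, compound 3 has only a limit and not a number, > 8.75 mg/kg. Compound 4 `COc1cc2nc(O)nc(-c3ccccc3)c2cc1OC` has phenyl in place of cyclopentyl on an aromatic carbon. All three measured steps involve a change of group at this same place. The step of a 1.7-fold lower number from compound 1 to compound 2 (0.24 log units; within the scatter) lies within the scatter. Cyclopentyl gave larger steps, an at least 3.6-fold higher number from compound 1 to compound 3 (0.55 log units; beyond the scatter) and an at least 6.2-fold higher number from compound 2 to compound 3 (0.79 log units; beyond the scatter), both beyond the scatter. Among the compounds with values here, no measured step introduces phenyl, so these steps offer only indirect guidance. Compound 4 need not share the high number of compound 3, and a partial return towards the range of the two smaller groups is expected, though with wide uncertainty. The expected change is an at least 2.5-fold lower number from compound 3 to compound 4 (0.39 log units; beyond the scatter), towards a lower number. For compound 4 the estimate is 3.5 mg/kg, with an expected range from 1.2 mg/kg to 9 mg/kg.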

Compound 4, dose for half-maximal effect: 4.1 mg/kg
Compound 4: the middle estimate sits 1.2-fold (0.07 log units) below what was measured; low and high end bracket the measured number.
By their numbers in this assay, from the lowest: compounds 2, 1 and 4 (each within the scatter of the next, the first and the last beyond it). At a limit, above all of these: compound 3.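

In this assay, the change from cyclopentyl to phenyl gives an at least 2.1-fold lower number from compound 3 to compound 4 (0.32 log units; beyond the scatter), so a ring on this aromatic carbon need not carry the high number of compound 3, and the number does not simply follow the heavy-atom count, with 6 in phenyl against 5 in cyclopentyl. Compound 3 remains a limit and not a number: the limit of > 8.75 mg/kg in this assay, at which 1 of the 4 values shown sits. Phenyl stands apart from isopropyl, with a 2.9-fold higher number from compound 2 to compound 4 (0.47 log units; beyond the scatter), but not from methyl, with a 1.7-fold higher number from compound 1 to compound 4 (0.23 log units; within the scatter), so the position accepts an aromatic ring while staying on the side of the isopropyl compound's number that the methyl compound's scatter also reaches.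

Going by these compounds, the true number of compound 3 stays open, so its step is known only as a bound. Also open, on these data alone, is how a pyridine ring, a methoxy-substituted phenyl or an amine would behave at this place.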